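This account rests on a few compounds, and the source may have more. Where it says the series, first, only, none or still open, it means among the compounds named here.

Within the data shown here, in a physicochemical assay for solubility, in phosphate buffer, with a stated time of 18 h, at pH 7.4 (a lower number here means a less soluble compound, a higher number a more soluble compound), compound 1 (`CCN(CC)C(=O)COc1cc2c(-n3nc(-c4ccccn4)nc3N)ncnc2cc1OC`) gives 42000 nM and compound 2 (`COc1cc2ncnc(-n3nc(-c4ccccn4)nc3N)c2cc1OCCCNC(=O)OC(C)C`) gives 18000 nM, the lower of the two numbers so far. Next, compound 3 (`COc1cc2ncnc(-n3nc(-c4ccccn4)nc3N)c2cc1OCCCNC(=O)OCC(F)(F)F`) carries 2,2,2-trifluoroethyl in place of isopropyl on an oxygen next to a carbonyl group. Among the measured compounds shown here, the only measured step, a 2.3-fold lower number from compound 1 to compound 2 (0.37 log units; beyond the scatter), replaced a larger part of the side chain and gives only a rough scale. A modest step at most is therefore expected in this assay, tentatively towards a lower number. The estimated step is a 1.5-fold lower number from compound 2 to compound 3 (0.18 log units; within the scatter). For compound 3 the expected value is 12000 nM, with an estimated range of 4500 nM to 30000 nM.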

Compound 3, solubility: 100 nM
For compound 3 the middle estimate is 120-fold (2.08 log units) above the measured one; the measured number lies below the stated range.
By their numbers in this assay, from the lowest: compound 3; then compound 2; then compound 1.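

At this place, on an oxygen next to a carbonyl group, 2,2,2-trifluoroethyl in place of isopropyl gives a 180-fold lower number from compound 2 to compound 3 (2.26 log units; beyond the scatter) in this assay, so a change to this one group can move the number by a large step. The wider change from the diethylcarbamoyl side chain gives a 420-fold lower number from compound 1 to compound 3 (2.62 log units; beyond the scatter), and most of that distance lies in this single swap. Nothing measured here bears on the reason for the fall. Open, going by these compounds, is whether the fall follows the fluorine atoms or the ethyl chain itself, which a plain ethyl group on the same oxygen would separate. Also open, on these data alone, is how an amine at this place would read.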